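This account rests on a few compounds, and the source may have more. Where it says the series, first, only, none or still open, it means among the compounds named here.

The measured compounds in a physicochemical assay for solubility; on this read-out higher numbers stand for higher solubility and lower numbers for lower solubility:

compound 1, `CNC(=O)c1cc(C(=O)NC2CC2)cn(CC2CCCCC2)c1=O`: >= 148 ug/mL (a limit)
compound 2, `CNC(=O)c1ccc(=O)n(Cc2ccccc2)c1`: >= 108 ug/mL (a limit)
compound 3, `CNC(=O)c1cc(C(=O)NCCC(C)C)cn(Cc2ccccc2)c1=O`: 10 ug/mL

In this assay compound 1 reaches only a limit, >= 148 ug/mL, and no number. Compound 2 likewise stops at a limit, >= 108 ug/mL. Compound 3 alone gives a number, 10 ug/mL. Compound 1 thus stands at the top of what is shown, on (the limit of >= 148 ug/mL in this assay, at which 1 of the 3 values shown sits), while compound 2 sits on (the limit of >= 108 ug/mL in this assay, at which 1 of the 3 values shown sits); how far compound 1 lies above compound 3 cannot be told from a limit.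

The next compound is compound 4, `CNC(=O)c1cc(C(=O)NC2CC2)cn(Cc2cccc3occc23)c1=O`. It differs from compound 1 in one place: 1-benzofuran-4-yl in place of cyclohexyl on a saturated chain carbon bound to an aromatic nitrogen. Among the compounds with values here, no measured pair shows this change, so its size is not known. Since compound 1 stands at a limit, the account expects the step from compound 1 to compound 4 to run downward, beyond the usual scatter, with compound 4 landing between the limit of compound 1 and the number of compound 3. Compound 4 is therefore estimated at 40 ug/mL, in the range 10 ug/mL to 148 ug/mL. That estimate means a step of an at least 3.7-fold lower number from compound 1 to compound 4 (0.56 log units; beyond the scatter) is expected.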

Compound 4, solubility: >= 110 ug/mL
Compound 4: only a limit was reported; the forecaster's own chance of this, stated with the estimate: 20%; at least 2.7-fold (0.43 log units) between middle value and limit.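

In this assay, compound 1 and compound 4 each reach only a limit, and no step can be read between them. The compounds shown leave open the size and even the direction of the change from cyclohexyl to 1-benzofuran-4-yl on this read-out.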